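Aryl swap on a nucleoside core: working notes

The compounds below may be only part of what the source reports. "The series", "measured", "known", "first", "only" and "open" are said of these compounds alone.

Measured compounds:
Compound 1 `Nc1nc(N)c2c(-c3ccsc3)cn([C@@H]3O[C@H](CO)[C@@H](O)[C@H]3O)c2n1`. In a functional assay on HCT-116 cells (Homo sapiens), read by MTT assay, with a stated time of 72 h (on this read-out higher numbers stand for weaker inhibition and lower numbers for stronger inhibition), compound 1 gives > 20000 nM, which is a limit of the assay and not a number.
Compound 2 `Nc1nc(N)c2c(-c3ccccc3)cn([C@@H]3O[C@H](CO)[C@@H](O)[C@H]3O)c2n1`. In this assay compound 2 gives > 20000 nM, again only a limit.
Compound 3 `Nc1nc2c(c(-c3ccccc3)cn2[C@@H]2O[C@H](CO)[C@@H](O)[C@H]2O)c(=O)[nH]1`. In this assay compound 3 gives > 20000 nM, also a limit.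

Compound 1 and compound 2 share one core and differ in a single place: thiophen-3-yl in place of phenyl on an aromatic carbon. The step that the two limits leave unreadable from compound 2 to compound 1 stays unreadable because of the limit of > 20000 nM in this assay, at which 3 of the 3 values shown sit; no direction or size can be taken from it. Compound 3 carries a different core from compound 2, and the difference between the two cores is not broken down here. All three measured values sit at the same limit, so nothing separates the compounds from one another in this assay.

Compound 4 `Nc1nc2c(c(-c3ccsc3)cn2[C@@H]2O[C@H](CO)[C@@H](O)[C@H]2O)c(=O)[nH]1` has not yet been measured in this assay. It differs from compound 3 by thiophen-3-yl in place of phenyl on an aromatic carbon, which is the same change as from compound 2 to compound 1, at the same place on the core. For the measured compounds named here, the only guide is that compound 3 sits at the limit and that the same change on the other core did not move compound 2 to a readable number. The step that the limit leaves unreadable from compound 3 to compound 4 is therefore expected to be flat. Compound 4 is expected at 30000 nM, in a range from 12000 nM to 100000 nM, and most probably the assay will again report only a limit.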

Compound 4, half-maximal inhibitory concentration: > 20000 nM
Compound 4 was reported as a limit; the forecaster's own chance of this, stated with the estimate: 85%; the middle value lies beyond the limit too.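

In this assay compound 4 gives > 20000 nM, again a limit of the assay and not a number. No step can be read from compound 3 to compound 4, because the comparison rests on limits alone: the limit of > 20000 nM in this assay, at which 4 of the 4 values shown sit.

The compounds shown leave open whether thiophen-3-yl in place of phenyl, or the difference between the two cores, has any effect on a readable number in this assay.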